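The compounds below may be only part of what the source reports. "The series", "measured", "known", "first", "only" and "open" are said of these compounds alone.

In a functional assay on ZR-75-1 cells (Homo sapiens) for inhibition, read by MTT assay, with a stated time of 24 h (a lower number here means a stronger inhibitor of growth, a higher number a weaker inhibitor of growth), compound 1 (`N[C@@H](CCC(=O)O[C@H]1C[C@H](n2cc(F)c(=O)[nH]c2=O)O[C@@H]1CO)C(=O)O`) gives 1600000 nM and compound 2 (`N[C@@H](CC(=O)O[C@H]1C[C@H](n2cc(F)c(=O)[nH]c2=O)O[C@@H]1CO)C(=O)O`) gives 3100000 nM, so compound 2 stands level with compound 1 within the scatter. Compound 3 (`CC(C)[C@H](N)C(=O)O[C@H]1C[C@H](n2cc(F)c(=O)[nH]c2=O)O[C@@H]1CO`) differs from compound 2 by one change: 1-amino-2-methylpropyl in place of 2-amino-2-carboxyethyl on a carbonyl carbon. Among the measured compounds shown here, the only measured step, a 1.9-fold higher number from compound 1 to compound 2 (0.29 log units; within the scatter), swaps amino(carboxy)methyl for 2-amino-2-carboxyethyl and does not test this replacement, so it offers weak guidance. In this assay a modest move towards a lower number is expected, a 2.2-fold lower number from compound 2 to compound 3 (0.35 log units; beyond the scatter). For compound 3 the estimated value is 1400000 nM, with an expected range of 300000 nM to 4000000 nM.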

Compound 3, concentration for 50% growth inhibition: 2100000 nM
Compound 3: the middle estimate sits 1.5-fold (0.18 log units) below what was measured; low and high end bracket the measured number.
By their numbers in this assay, from the lowest: compounds 1, 3 and 2 (each within the scatter of the next).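

In this assay on this carbonyl carbon, 1-amino-2-methylpropyl replaces 2-amino-2-carboxyethyl with a 1.5-fold lower number from compound 2 to compound 3 (0.17 log units; within the scatter) and replaces 3-amino-3-carboxypropyl with a 1.3-fold higher number from compound 1 to compound 3 (0.12 log units; within the scatter) as well. The carboxy group of the earlier chains is therefore not required to keep the number at this level, which compound 1 and compound 2 alone could not show. Nothing available explains these numbers.

Still open, going by these compounds, is whether the amine on the chain matters. A plain alkyl chain or a phenyl-bearing chain at this carbonyl carbon might yet give a number beyond the scatter of these three.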